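Sulfonyl aryl exchange in a series at the assay limit

The source may report more compounds than this note shows. Statements on the series, on what has been measured and on what is new or still open speak of the compounds shown alone.

compound 1 `O=S(=O)(Nc1ccc2oc(-c3ccccc3)nc2c1)c1ccc(Cl)cc1` — > 100000 nM
compound 2 `O=S(=O)(Nc1ccc2oc(-c3ccccc3)nc2c1)c1ccc(Cl)c(C(F)(F)F)c1` — > 100000 nM

In an assay on cells for inhibition of HSP60/HSP10 (Homo sapiens), with a stated time of 60 min (on this read-out higher numbers stand for weaker inhibition and lower numbers for stronger inhibition), compound 1 gives > 100000 nM, which is a limit of the assay and not a number. Compound 2 gives > 100000 nM, likewise a limit. The step that the two limits leave unreadable from compound 1 to compound 2, trifluoromethyl in place of hydrogen on an aromatic carbon, is unreadable because both values sit at the limit of > 100000 nM in this assay, at which 2 of the 2 values shown sit. So compound 1 stands at the limit, with no number of its own.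

Compound 3 `Cc1cccc(S(=O)(=O)Nc2ccc3oc(-c4ccccc4)nc3c2)c1` is not yet measured. It differs from compound 1 by 3-methylphenyl in place of 4-chlorophenyl on a sulfonyl sulfur. Within the data shown here, no measured step touches this change, and the single measured step gives no readable size, so there is no basis for expecting movement beyond the scatter. Compound 3 is therefore expected to give about 150000 nM, within 40000 nM to 500000 nM, most likely again reported only as a limit. The expected step that the limit leaves unreadable from compound 1 to compound 3 is thus estimated as none beyond the scatter.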

Compound 3, half-maximal inhibitory concentration: > 100000 nM
Compound 3 was reported as a limit (the forecaster's own chance of this, stated with the estimate: 85%); the middle value lies beyond the limit too.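

In this assay compound 3 gives > 100000 nM, a limit and not a number, so the exchange relative to compound 1 yields no readable step: the limit of > 100000 nM in this assay, at which 3 of the 3 values shown sit.

The compounds shown leave open whether any group on the sulfonyl sulfur would bring the shared core to a measurable value.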